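This account rests on a few compounds, and the source may have more. Where it says the series, first, only, none or still open, it means among the compounds named here.

Compound 1 `Cn1cncc1C(O)(c1ccc(C#N)cc1)c1cc2cc([N+](=O)[O-])cc(-c3ccccc3F)c2o1`: 89.5 nM
Compound 2 `Cn1cncc1C(O)(c1ccc(Cl)cc1)c1cc2cc([N+](=O)[O-])cc(-c3ccccc3)c2o1`: 1890 nM

Both compounds were tested in a functional assay on QG-56 cells (Homo sapiens) for antiproliferative activity; a lower number here means a stronger inhibitor, a higher number a weaker inhibitor. Compound 1, at 89.5 nM, holds the lower of the two numbers, and the gap up to compound 2 lies beyond the scatter. These two differ in more than one place, so their gap does not isolate any single change. Compound 3 `Cn1cncc1C(O)(c1ccc(C#N)cc1)c1cc2cc([N+](=O)[O-])cc(-c3ccc(F)cc3)c2o1` keeps the core of compound 1 but carries 4-fluorophenyl in place of 2-fluorophenyl on an aromatic carbon. Within the data shown here, no measured pair shows this change, so only a moderate, uncertain move towards a weaker number in this assay is expected. The estimated change is a 2.2-fold higher number from compound 1 to compound 3 (0.35 log units; beyond the scatter). The expected value for compound 3 is 200 nM, with an estimated range from 50 nM to 800 nM.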

Compound 3, half-maximal inhibitory concentration: 158 nM
Compound 3: middle estimate off by 1.3-fold (0.10 log units), on the high side; measured number inside the range.
By their numbers in this assay, from the lowest: compounds 1 and 3 (each within the scatter of the next); then compound 2.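

In this assay, 4-fluorophenyl in place of 2-fluorophenyl gives a 1.8-fold higher number from compound 1 to compound 3 (0.25 log units; within the scatter), so at this position the two fluorophenyl groups cannot be told apart. Among these compounds, this is the first comparison here that isolates a single change, which the gap to compound 2 could not do. No measured evidence bears on this result.

Still open, going by these compounds, is how the number would respond to 3-fluorophenyl or plain phenyl on the core of compound 1. Also open, on these data alone, is whether a larger change at this position, such as a pyridine ring or an amine, would shift it beyond the scatter.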